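The source may report more compounds than this note shows. Statements on the series, on what has been measured and on what is new or still open speak of the compounds shown alone.

Three compounds share one core. Compound 1 `CCc1cc(C(C)=O)c(O)cc1OCCCCCCC(C)(C)C#N` gives 11% in an assay on isolated protein for binding affinity to leukotriene B4 receptor (Homo sapiens), tested at 0.1 uM; on this read-out lower numbers stand for less inhibition and higher numbers for more inhibition at the one concentration tested (going by the name of the read-out). Compound 2 `CCc1cc(C(C)=O)c(O)cc1OCCCCCCCC(C)(C)C#N` gives 6%, and compound 3 `CCc1cc(C(C)=O)c(O)cc1OCCCCCCC(C)(C)c1nnn[nH]1` gives 13%; the steps of a number 5 percentage points lower from compound 1 to compound 2 (within the scatter), a number 2 percentage points higher from compound 1 to compound 3 (within the scatter) and a number 7 percentage points higher from compound 2 to compound 3 (within the scatter) all lie within the scatter, so the three stand level. Compound 4 `CCc1cc(C(C)=O)c(O)cc1OCCCCCC(C)(C)c1nnn(C)n1` is not yet measured; its change from compound 3 is 1-methyl-1-(2-methyl-2H-tetrazol-5-yl)ethyl in place of 2-(1H-tetrazol-5-yl)-2-methylpropyl on a saturated chain carbon, five bonds along the chain from an oxygen on an aromatic ring. Among the measured compounds shown here, no measured step alters the tetrazole itself, and the nearest comparison, a tetrazole for a nitrile in the step of a number 2 percentage points higher from compound 1 to compound 3 (within the scatter), stayed within the scatter. Compound 4 is therefore expected to stay near compound 3, with a step of a number 2 percentage points lower from compound 3 to compound 4 (within the scatter). Compound 4 is estimated at 11%, between 0% and 25%.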

Compound 4, a percentage reported as inhibition, at one concentration (the size of the read-out at that concentration, not a potency): 16%
The estimate for compound 4 lay 5 percentage points below the measured number, within the range that was stated.
By their numbers in this assay, from the lowest: compounds 2, 1, 3 and 4 (each within the scatter of the next).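

In this assay, the loss of the tetrazole hydrogen-bond donor, with 0 donors in the entering 1-methyl-1-(2-methyl-2H-tetrazol-5-yl)ethyl against 1 in the leaving group, comes with a number 3 percentage points higher from compound 3 to compound 4 (within the scatter). Measured against the two nitriles, the methylated tetrazole also stays within the scatter, with a number 10 percentage points higher from compound 2 to compound 4 (within the scatter) and a number 5 percentage points higher from compound 1 to compound 4 (within the scatter), so all four compounds stand level. Nothing measured offers an explanation for this result.

The compounds shown leave open whether a carboxylic acid or an amine on this saturated chain carbon would move the number beyond the scatter.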